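Replacing the fused bicyclic amine in a nitro sulfone benzamide series

The source may report more compounds than this note shows. Statements on the series, on what has been measured and on what is new or still open speak of the compounds shown alone.

Compound 1, `CS(=O)(=O)c1ccc(C(=O)NCCC(=O)N2CCCc3ccccc32)cc1[N+](=O)[O-]`, in an assay on isolated protein for inhibition of vitamin D3 receptor (Homo sapiens), read by fluorescence polarization (a higher number here means a weaker inhibitor, a lower number a stronger inhibitor), gives > 60000 nM, which is a limit of the assay and not a number.
Compound 2, `CS(=O)(=O)c1ccc(C(=O)N2CCC(C(=O)N3CCC(c4ccccc4)CC3)CC2)cc1[N+](=O)[O-]`, in this assay gives > 60000 nM, likewise a limit.

Among the measured compounds shown here, compound 1 therefore stands nowhere on a scale of numbers: its result is a limit, and the only other value shown is a limit as well. Compound 1 sits at the limit of > 60000 nM in this assay, at which 2 of the 2 values shown sit. For the measured compounds named here, no pair of measured compounds differs in a single place, so no measured step exists from which the effect of a structural change could be read.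

Compound 3, `CC1CCN(C(=O)CCNC(=O)c2ccc(S(C)(=O)=O)c([N+](=O)[O-])c2)CC1`, differs from compound 1 by 4-methylpiperidin-1-yl in place of 1,2,3,4-tetrahydroquinolin-1-yl on a carbonyl carbon. Going by the values given here, with both known values at the limit, no step in this assay beyond the scatter can be foreseen in either direction, and compound 3 is expected to return a limit again. Compound 3 is estimated at 80000 nM, with a range from 30000 nM to 250000 nM. The expected step is a step that the limit leaves unreadable from compound 1 to compound 3.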

Compound 3, half-maximal inhibitory concentration: > 60000 nM
Compound 3 was reported as a limit (the forecaster's own chance of this, stated with the estimate: 85%); the middle value does not contradict the limit.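

Compound 1 and compound 3 both return only limits in this assay, so no step between them can be read: the limit of > 60000 nM in this assay, at which 3 of the 3 values shown sit.

The compounds shown leave open whether any change to the shared core would give a measurable value.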